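The compounds below may be only part of what the source reports. "The series", "measured", "known", "first", "only" and "open" are said of these compounds alone.

In a functional assay on MKN-45 cells (Homo sapiens) for antiproliferative activity (a lower number here means a stronger inhibitor, a higher number a weaker inhibitor), three compounds on a shared core have been measured. Compound 1 `COc1ccc(S(=O)(=O)N2CCc3cccc(Nc4ccc(O)cc4)c32)cc1` gives 493 nM, compound 2 `COc1ccc(Nc2cccc3c2N(S(=O)(=O)c2ccc(OC)cc2)CC3)cc1` gives 487 nM, and compound 3 `COC(=O)c1ccc(Nc2cccc3c2N(S(=O)(=O)c2ccc(OC)cc2)CC3)cc1` gives 487 nM. Compound 3 is thus level with compound 2 and within the scatter of compound 1.

Compound 4 `COc1ccc(S(=O)(=O)N2CCc3cccc(Nc4ccc(C(=O)O)cc4)c32)cc1` differs from compound 3 by hydrogen in place of methyl on an oxygen next to a carbonyl group, with hydrogen in place of methyl on an oxygen next to a carbonyl group, so that methoxycarbonyl becomes carboxy. The closest measured parallel, methyl in place of hydrogen on an oxygen on an aromatic ring, gave a 1.0-fold lower number from compound 1 to compound 2 (0.01 log units; within the scatter). Exchanges at the same ring position gave a 1.0-fold lower number from compound 1 to compound 3 (0.01 log units; within the scatter) and no change at the digits printed from compound 2 to compound 3 (within the scatter). All three steps lie within the scatter.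

Among the compounds with values here, no measured compound carries carboxy, so this evidence is only indirect. A step within the scatter is expected, with a slight allowance toward a higher number. The estimated step is a 1.3-fold higher number from compound 3 to compound 4 (0.13 log units; within the scatter). Compound 4 is expected at 650 nM, with an estimated range of 280 nM to 2200 nM.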

Compound 4, half-maximal inhibitory concentration: 1390 nM
The estimate for compound 4 lay 2.1-fold (0.33 log units) below the measured number; low and high end bracket the measured number.
By their numbers in this assay, from the lowest: compounds 2, 3 and 1 (each within the scatter of the next); then compound 4.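

Hydrogen in place of methyl on an oxygen next to a carbonyl group, which turns methoxycarbonyl into carboxy, is the first change in this assay to go beyond the scatter, with a 2.9-fold higher number from compound 3 to compound 4 (0.46 log units; beyond the scatter). Carboxy also separates from the other groups on this aromatic carbon, with a 2.9-fold higher number from compound 2 to compound 4 (0.46 log units; beyond the scatter) and a 2.8-fold higher number from compound 1 to compound 4 (0.45 log units; beyond the scatter), whereas hydroxy, methoxy and methoxycarbonyl had stayed within the scatter of one another. The same exchange of methyl and hydrogen on an oxygen therefore does not read across from the hydroxy and methoxy pair to the carboxy and methoxycarbonyl pair: the same change on two cores in this assay, a 1.0-fold lower number (0.01 log units; within the scatter) from compound 1 to compound 2 and a 2.9-fold lower number (0.46 log units; beyond the scatter) from compound 4 to compound 3, 2.8-fold (0.45 log units) apart, beyond the scatter of two such steps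

The compounds shown leave open whether the higher number belongs to carboxy alone or would also come with a primary amide or an amine on the same aromatic carbon. They also leave open whether a carboxylic acid at the end of a longer chain there would read like compound 4 or like the other three.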